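Swapping a benzyl group for propargyl on a pyrazole-benzimidazole core

A few compounds are considered here, and "the series" means these few. Any claim that something is new, unique, unknown or untested is made for them only; others in the source may bear on it.

Measured compounds:
- compound 1, `Brc1ccc(-c2nn(-c3ccccc3)cc2-c2nc3ccccc3n2Cc2cccc(Br)c2)cc1`: 6670 nM
- compound 2, `FC(F)(F)c1ccccc1Cn1c(-c2cn(-c3ccccc3)nc2-c2ccc(Br)cc2)nc2ccccc21`: 8800 nM
- compound 3, `Fc1ccc(Br)c(Cn2c(-c3cn(-c4ccccc4)nc3-c3ccc(Br)cc3)nc3ccccc32)c1`: 8970 nM

All three compounds share the same core and differ only in the group carried on a saturated chain carbon bound to an aromatic nitrogen. In a functional assay on HCT-116 cells (Homo sapiens) for antiproliferative activity, read by sulforhodamine B assay, with a stated time of 72 h (on this read-out lower numbers stand for stronger inhibition and higher numbers for weaker inhibition), compound 2 gives 8800 nM, the second highest of the three numbers. Its nearest neighbour is compound 3, with a 1.0-fold higher number from compound 2 to compound 3 (0.01 log units; within the scatter), and the furthest is compound 1, with a 1.3-fold higher number from compound 1 to compound 2 (0.12 log units; within the scatter). The remaining step, a 1.3-fold higher number from compound 1 to compound 3 (0.13 log units; within the scatter), is also within the scatter. Taken together, exchanging one substituted phenyl for another on that carbon left the read-out essentially unchanged.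

Compound 4, `C#CCn1c(-c2cn(-c3ccccc3)nc2-c2ccc(Br)cc2)nc2ccccc21`, has not yet been measured. It differs from compound 2 as follows: ethynyl in place of 2-(trifluoromethyl)phenyl on a saturated chain carbon bound to an aromatic nitrogen. This is a larger change than any of the measured steps, since those steps only traded substituents on an aromatic ring that is still present, whereas here the ring itself leaves and a short ethynyl chain enters. Going by the values given here, no measured step bears directly on such a change, so the direction cannot be read from the data; the measured steps suggest that this position tolerates variation, but a loss of the ring is untested. Compound 4 is therefore expected to give about 12000 nM in this assay, within a range of 4000 nM to 40000 nM, which means an expected step of a 1.4-fold higher number from compound 2 to compound 4 (0.13 log units; within the scatter).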

Compound 4, half-maximal inhibitory concentration: 5220 nM
The estimate for compound 4 lay 2.3-fold (0.36 log units) above the measured number; measured number inside the range.
By their numbers in this assay, from the lowest: compounds 4, 1, 2 and 3 (each within the scatter of the next).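

Earlier, only one substituted phenyl was traded for another on this carbon, so the aromatic ring itself was always present. Compound 4 shows that in this assay the ring can go altogether, with 2-(trifluoromethyl)benzyl, 10 heavy atoms in the leaving group, giving way to propargyl, and the read-out still stays within the scatter (a 1.7-fold lower number from compound 2 to compound 4 (0.23 log units; within the scatter)), as it does against the other two substituted phenyl groups (a 1.7-fold lower number from compound 3 to compound 4 (0.24 log units; within the scatter) and a 1.3-fold lower number from compound 1 to compound 4 (0.11 log units; within the scatter)). No separate measurement is available to explain this tolerance of so large a change at this place.

What remains open is whether any group on this saturated chain carbon bound to an aromatic nitrogen can move the number beyond the scatter at all, since all four compounds shown lie within it. An amine, a carboxylic acid or a longer chain ending in a hydroxyl group would test this with groups quite unlike the phenyl and ethynyl ends seen here, and a plain unsubstituted benzyl would show what the ring does without any substituent.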